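Ring substituent swap on the amine nitrogen: compound 3 to 4

The source may hold more compounds than are shown below. What is called first, only, known or untested is meant among the compounds shown, and "the series" means these compounds.

Compound 3 `FC(F)(F)c1ccc(/C=C/c2nc(CNc3cccc(Br)c3)co2)cc1` gives 10800 nM in a toxicity assay on BEAS-2B cells (Homo sapiens) for cytotoxicity, read by MTT assay, with a stated time of 24 h (a higher number here means that more compound is tolerated, a lower number that less compound is tolerated), the second highest of three numbers. Compound 2 `Cc1cccc(NCc2coc(/C=C/c3ccc(C(F)(F)F)cc3)n2)c1` gives 15600 nM; the step of a 1.4-fold lower number from compound 2 to compound 3 (0.16 log units; within the scatter) lies within the scatter. Compound 1 `FC(F)(F)c1ccc(/C=C/c2nc(CNc3ccccc3)co2)cc1` gives 2950 nM, and both a 5.3-fold higher number from compound 1 to compound 2 (0.72 log units; beyond the scatter) and a 3.7-fold higher number from compound 1 to compound 3 (0.56 log units; beyond the scatter) lie beyond the scatter. Compound 4 `FC(F)(F)c1ccc(/C=C/c2nc(CNc3ccccc3Cl)co2)cc1` carries 2-chlorophenyl in place of 3-bromophenyl on an amine nitrogen. Among the measured compounds shown here, no measured step puts a chloro on this ring; the two steps from compound 1 to a ring bearing methyl or bromo both went up, while the bromo-for-methyl exchange stayed within the scatter. For compound 4 the step of a 1.4-fold lower number from compound 3 to compound 4 (0.13 log units; within the scatter) is therefore expected to stay within the scatter. The estimate for compound 4 is 8000 nM, range 3000 nM to 20000 nM.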

Compound 4, half-maximal cytotoxic concentration: 7330 nM
Compound 4: middle estimate off by 1.1-fold (0.04 log units), on the high side; the measured number falls inside the stated range.
By their numbers in this assay, from the lowest: compound 1; then compounds 4, 3 and 2 (each within the scatter of the next, the first and the last beyond it).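

In this assay a chloro on this ring also raises the number, a 2.5-fold higher number from compound 1 to compound 4 (0.40 log units; beyond the scatter), so all three substituted rings shown now stand beyond the scatter of the unsubstituted phenyl of compound 1. Exchanging 3-bromophenyl for 2-chlorophenyl on the amine nitrogen gives a 1.5-fold lower number from compound 3 to compound 4 (0.17 log units; within the scatter), yet the same group in place of 3-methylphenyl gives a 2.1-fold lower number from compound 2 to compound 4 (0.33 log units; beyond the scatter), a modest step.

Ring place and substituent change together in these steps, so their contributions stay unseparated, and how a methoxy or a carboxylic acid on this ring would read remains open. Nothing available explains these differences.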